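This account rests on a few compounds, and the source may have more. Where it says the series, first, only, none or still open, it means among the compounds named here.

Measured compounds:
Compound 1 `O=S(=O)(Oc1ccc(F)cc1)C1CC2OC1C(c1ccc(/C=C/c3cc(O)cc(O)c3)cc1)=C2c1ccc(O)cc1`, in a functional assay on MCF7 cells (Homo sapiens) for antiproliferative activity, read by MTT assay, with a stated time of 72 h (a higher number here means a weaker inhibitor, a lower number a stronger inhibitor), compound 1 gives 13100 nM.
Compound 2 `O=S(=O)(Oc1ccc(O)cc1)C1CC2OC1C(c1ccc(/C=C/c3cc(O)cc(O)c3)cc1)=C2c1ccc(O)cc1`, in this assay compound 2 gives 14100 nM.

Compound 1 has the lowest of the two numbers in this assay, with compound 2 nearest: a 1.1-fold higher number from compound 1 to compound 2 (0.03 log units; within the scatter). The two compounds differ only in the hydroxy in place of fluoro on an aromatic carbon, and that step lies within the scatter.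

Compound 3 `O=S(=O)(Oc1cccc2ccccc12)C1CC2OC1C(c1ccc(/C=C/c3cc(O)cc(O)c3)cc1)=C2c1ccc(O)cc1` differs from compound 1 by naphthalen-1-yl in place of 4-fluorophenyl on an oxygen. Among the measured compounds shown here, no measured pair shows this change. For the measured compounds named here, the only step that bears on it is the one from compound 1 to compound 2, which alters the same part of the molecule and left the number essentially unchanged: a 1.1-fold higher number from compound 1 to compound 2 (0.03 log units; within the scatter). On that basis the expected step in this assay from compound 1 to compound 3 is a 1.1-fold lower number from compound 1 to compound 3 (0.04 log units; within the scatter), with no direction beyond the scatter. Compound 3 is therefore estimated at 12000 nM, within a range of 4000 nM to 40000 nM.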

Compound 3, half-maximal inhibitory concentration: 11000 nM
For compound 3 the middle estimate is 1.1-fold (0.04 log units) above the measured one; measured number inside the range.
By their numbers in this assay, from the lowest: compounds 3, 1 and 2 (each within the scatter of the next).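

The earlier pair changed only one substituent on the aromatic ring, whereas compound 3 replaces the whole 4-fluorophenyl on the oxygen bound to the sulfonyl sulfur with naphthalen-1-yl, which brings a second six-membered aromatic ring. Even this larger change gives a 1.2-fold lower number from compound 1 to compound 3 (0.08 log units; within the scatter) in this assay, and naphthalen-1-yl in place of 4-hydroxyphenyl gives a 1.3-fold lower number from compound 2 to compound 3 (0.11 log units; within the scatter) in the same read-out, so all three groups on this oxygen fall within the scatter of one another. Nothing available accounts for this lack of separation.

All three groups shown are aromatic, so it remains open whether a group of another kind on this oxygen, such as a longer alkyl chain, would shift the number beyond the scatter. Going by these compounds, a phenyl ring bearing an amine or a carboxylic acid also remains untested here.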